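The source may report more compounds than this note shows. Statements on the series, on what has been measured and on what is new or still open speak of the compounds shown alone.

Compound 1 `Cc1cc(C(=O)O)ccc1OCCCCOc1ccc(C(=O)CC(C)C)c(O)c1C` and compound 2 `CCCC(=O)c1ccc(OCCCCOc2ccc(C(=O)O)cc2C)c(C)c1O` share one core and were both tested in an assay on HEK293 cells for positive allosteric modulation of metabotropic glutamate receptor 2 (Rattus norvegicus), read by thallium flux, with a stated time of 2.5 min; on this read-out lower numbers stand for an effect already at smaller amounts and higher numbers for an effect only at larger amounts of compound. In this assay compound 1 gives 192 nM, and compound 2 gives 104 nM. Among the measured compounds shown here, the only step between them, a 1.8-fold lower number from compound 1 to compound 2 (0.27 log units; within the scatter), is the single comparison available, and it leaves compound 1 and compound 2 within the usual scatter of each other, so neither stands apart.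

Compound 3 `Cc1ccc(C(=O)O)cc1OCCCCOc1ccc(C(=O)CC(C)C)c(O)c1C` has not yet been measured. It differs from compound 1 in one place only: 5-carboxy-2-methylphenyl in place of 4-carboxy-2-methylphenyl on an oxygen on a saturated carbon. The carboxy group thus moves on the same ring, while the rest of the molecule is unchanged.

For the measured compounds named here, no measured step bears on this change. The step from compound 1 to compound 2 concerns the chain on the ketone, not the ring that carries the carboxy group, so it offers no guide here. With no evidence either way, the most defensible expectation is a number close to that of compound 1, with a wide range to allow for an unexpected effect in either direction. Compound 3 is therefore estimated at 250 nM, with a range from 80 nM to 900 nM, which means an expected step of a 1.3-fold higher number from compound 1 to compound 3 (0.11 log units; within the scatter).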

Compound 3, half-maximal effective concentration: 454 nM
The estimate for compound 3 lay 1.8-fold (0.26 log units) below the measured number; measured number inside the range.
By their numbers in this assay, from the lowest: compounds 2 and 1 (each within the scatter of the next); then compound 3.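

In this assay, among the compounds shown here, moving the carboxy group to another place on the same ring gives a 2.4-fold higher number from compound 1 to compound 3 (0.37 log units; beyond the scatter), the first step in this small set that lies beyond the usual scatter. The 4-carboxy-2-methylphenyl and 5-carboxy-2-methylphenyl groups have the same atoms and the same counts of hydrogen-bond donors and acceptors, so this modest step shows that the number responds to how the ring is arranged, not only to which atoms it carries. Nothing available explains why the 5-carboxy-2-methylphenyl arrangement gives the higher number.

As far as these compounds go, this single comparison rests on one ketone chain, so it remains open whether the same move would shift the number similarly on the chain carried by compound 2. Also open, from the compounds shown here alone, is whether the carboxy group itself is needed at either place, which a tetrazole or a primary amide in its place on the core of compound 1 could test, and such a replacement could show whether the number stays close to that of compound 1 or moves away from it.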